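This account rests on a few compounds, and the source may have more. Where it says the series, first, only, none or still open, it means among the compounds named here.

Working notes on the series, read in a functional assay on L1210 cells (Mus musculus) for antiproliferative activity; on this read-out higher numbers stand for weaker inhibition and lower numbers for stronger inhibition. Compound 1 `COc1cc(C(=O)c2sc(-c3ccc([N+](=O)[O-])cc3)cc2N)cc(OC)c1OC` gives 100 nM, compound 2 `COc1cc(C(=O)c2sc(-c3ccc(I)cc3)cc2N)cc(OC)c1OC` gives 400 nM, and compound 3 `COc1cc(C(=O)c2sc(-c3ccsc3)cc2N)cc(OC)c1OC` gives 12 nM. Compound 3 is therefore the most potent of the three, with its steps to both others beyond the scatter.

The next structure is compound 4 `COc1cc(C(=O)c2sc(-c3cccs3)cc2N)cc(OC)c1OC`: thiophen-2-yl in place of thiophen-3-yl on an aromatic carbon. Thiophen-2-yl replaces thiophen-3-yl, on the same aromatic carbon of the shared core.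

Among the measured compounds shown here, three measured steps bear on this place: an 8.3-fold lower number from compound 1 to compound 3 (0.92 log units; beyond the scatter), a 33-fold lower number from compound 2 to compound 3 (1.52 log units; beyond the scatter) and a 4.0-fold higher number from compound 1 to compound 2 (0.60 log units; beyond the scatter). They range from modest to large, so this assay responds clearly to the group held here. For the measured compounds named here, each of them exchanges more than compound 4 does, however, and no measured pair compares two thiophene attachments. A small step is therefore expected rather than a large one. As compound 3 already has the lowest number, at 12 nM, the direction is expected to be upward, though with little certainty.

The expected change is a 2.1-fold higher number from compound 3 to compound 4 (0.32 log units; beyond the scatter).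

For compound 4 the estimate is 25 nM, with an expected range of 7 nM to 100 nM.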

Compound 4, half-maximal inhibitory concentration: 9.8 nM
For compound 4 the middle estimate is 2.6-fold (0.41 log units) above the measured one, and the stated range covers the measured number.
By their numbers in this assay, from the lowest: compounds 4 and 3 (each within the scatter of the next); then compound 1; then compound 2.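

In this assay the point of attachment of the thiophene gives no readable difference at this position, with a 1.2-fold lower number from compound 3 to compound 4 (0.09 log units; within the scatter) and no order between thiophen-2-yl and thiophen-3-yl. The steps of a 10-fold lower number from compound 1 to compound 4 (1.01 log units; beyond the scatter) and a 41-fold lower number from compound 2 to compound 4 (1.61 log units; beyond the scatter) show that the distance from 4-nitrophenyl and 4-iodophenyl holds for thiophen-2-yl as it did for thiophen-3-yl, so it does not rest on a single thiophene attachment. No measurement on hand accounts for any of these differences.

Still open, going by these compounds, is whether an unsubstituted phenyl would sit with the two thiophenes or with compound 1 and compound 2. Also open, on these data alone, is whether the ring sulfur matters, which a furan-2-yl or a pyridin-3-yl at the same place would address.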